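This account rests on a few compounds, and the source may have more. Where it says the series, first, only, none or still open, it means among the compounds named here.

- Compound 1 `COc1ccc(S(=O)(=O)Nc2cccc3cc(O)[nH]c23)cc1`: 0.1 ug/mL
- Compound 2 `O=S(=O)(Nc1cccc2cc[nH]c12)c1ccc(Cl)cc1`: 6 ug/mL

Both compounds were tested in a functional assay on KB cells (Homo sapiens) for antiproliferative activity, read by colorimetric assay and MTT assay; on this read-out higher numbers stand for weaker inhibition and lower numbers for stronger inhibition. Compound 2 stands at the higher of the two numbers, 6 ug/mL, which makes it the weaker inhibitor of the pair, and its gap to compound 1 lies beyond the scatter. Compound 3 `O=S(=O)(Nc1cccc2cc(O)[nH]c12)c1ccc(Cl)cc1` differs from compound 2 in one place, with hydroxy in place of hydrogen on an aromatic carbon. Compound 1, which carries a hydroxy at that same place, reads 0.1 ug/mL, but it also differs from compound 2 elsewhere, so only part of that gap is expected to carry over. The expected change in this assay is a step toward stronger inhibition, beyond the scatter, with an estimated size of a 12-fold lower number from compound 2 to compound 3 (1.08 log units; beyond the scatter). Compound 3 is estimated at 0.5 ug/mL, with an expected range of 0.08 ug/mL to 3 ug/mL.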

Compound 3, half-maximal inhibitory concentration: 1.1 ug/mL
The estimate for compound 3 lay 2.2-fold (0.34 log units) below the measured number, within the range that was stated.
By their numbers in this assay, from the lowest: compound 1; then compound 3; then compound 2.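

With the chloro group held in place, hydroxy in place of hydrogen on the aromatic carbon next to the ring nitrogen can now be read on its own in this assay: it brings a 5.5-fold lower number from compound 2 to compound 3 (0.74 log units; beyond the scatter), a modest step. With the hydroxy held in place, compound 3 also isolates the second site, where chloro in place of methoxy on an aromatic carbon brings an 11-fold higher number from compound 1 to compound 3 (1.04 log units; beyond the scatter), a large step, so both places bear on the number in this assay. Nothing available explains either step.

From the compounds shown here alone, whether an amine at the hydroxy's place would give a step like the one seen with hydroxy remains open. Going by these compounds, it is also open how a nitrile in place of the chloro would read against the chloro and methoxy compounds.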